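Swapping the Sulfur-Linked Ring on a Shared Core

The compounds below may be only part of what the source reports. "The series", "measured", "known", "first", "only" and "open" are said of these compounds alone.

Compound 3 `Cn1c(-c2ccc(NC(=O)CSC3=NCCS3)cc2)nc(-c2ccccc2)c1-c1ccccc1` stands second highest of the three measured numbers in a functional assay on MCF7 cells (Homo sapiens) for cytotoxicity, read by MTT assay, with a stated time of 24 h, tested at 1.6 ug/mL (on this read-out lower numbers stand for a weaker effect and higher numbers for a stronger effect at the one concentration tested), where compound 3 gives 16.2%. Its nearest neighbour is compound 1 `Cc1ccc2oc(SCC(=O)Nc3ccc(-c4nc(-c5ccccc5)c(-c5ccccc5)n4C)cc3)nc2c1`, which in this assay gives 1.9%. The furthest is compound 2 `Cc1nnc(SCC(=O)Nc2ccc(-c3nc(-c4ccccc4)c(-c4ccccc4)n3C)cc2)s1`, which in this assay gives 37.5%. Every measured step changes the group carried on the sulfur: a number 35.6 percentage points higher from compound 1 to compound 2 (beyond the scatter), a number 14.3 percentage points higher from compound 1 to compound 3 (beyond the scatter) and a number 21.3 percentage points lower from compound 2 to compound 3 (beyond the scatter). Compound 4 `Cn1ccnc1SCC(=O)Nc1ccc(-c2nc(-c3ccccc3)c(-c3ccccc3)n2C)cc1` differs from compound 3 in that same place: a group of 6 heavy atoms (4 carbon, 2 nitrogen; one five-membered aromatic ring with 2 hetero atoms) in place of a group of 5 heavy atoms (3 carbon, 1 nitrogen, 1 sulfur; one five-membered non-aromatic ring with 2 hetero atoms), on a sulfur. Among the measured compounds shown here, the steps that bear on this are the two that also exchange the five-membered non-aromatic ring for an aromatic one: compound 2 lies higher than compound 3 by a number 21.3 percentage points lower from compound 2 to compound 3 (beyond the scatter) in reverse, while compound 1 lies lower by a number 14.3 percentage points higher from compound 1 to compound 3 (beyond the scatter) in reverse, so the direction is not settled by the data. Compound 4 is therefore expected to move only modestly upward, by a number 7.8 percentage points higher from compound 3 to compound 4 (within the scatter). Compound 4 is estimated at 24%, within a range of 5% to 48%.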

Compound 4, a percentage reported as activity, at one concentration (the size of the read-out at that concentration, not a potency): 17.5%
For compound 4 the middle estimate is 6.5 percentage points above the measured one; the range from low to high includes it.
By their numbers in this assay, from the lowest: compound 1; then compounds 3 and 4 (each within the scatter of the next); then compound 2.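

In this assay, the exchange on the sulfur gives a number 1.3 percentage points higher from compound 3 to compound 4 (within the scatter), so an aromatic five-membered ring with 2 hetero atoms does not by itself set this position apart from the non-aromatic ring. The aromatic groups do not read alike, however: 1-methyl-1H-imidazol-2-yl in place of 5-methyl-1,3,4-thiadiazol-2-yl gives a number 20 percentage points lower from compound 2 to compound 4 (beyond the scatter), while in place of 5-methyl-1,3-benzoxazol-2-yl it gives a number 15.6 percentage points higher from compound 1 to compound 4 (beyond the scatter). No evidence is available to explain these differences.

The compounds shown leave open whether the value of compound 2 depends on the methyl group of its 5-methyl-1,3,4-thiadiazol-2-yl ring or on the ring itself. They also leave open how an open-chain group on the sulfur, such as an aminoethyl or carboxymethyl chain, would compare.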